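Triazolylmethyl for cyanoguanidine in the fluoronaphthyl pyridinone series

The compounds below may be only part of what the source reports. "The series", "measured", "known", "first", "only" and "open" are said of these compounds alone.

Measured compounds:
- Compound 1 `CCn1ncc2c(F)cc(-c3ccc(C(CC)(CC)c4ncn(C)n4)c(=O)[nH]3)cc21`: in an ADME assay on microsomes from liver (Homo sapiens) for metabolic stability (a lower number here means that the compound disappears faster, a higher number that the compound lasts longer), compound 1 sits at a limit of the assay, > 3 h.
- Compound 2 `CC(C)C(c1ccc(-c2ccc3cccc(F)c3c2)[nH]c1=O)N1CCN/C1=N\C#N`: in this assay compound 2 gives 0.632 h.
- Compound 3 `CCC(CC)(c1nnc[nH]1)c1ccc(-c2ccc3cc(F)cc(F)c3c2)[nH]c1=O`: in this assay compound 3 gives 1.76 h.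

Compound 2 has the lowest of the two numbers; compound 3 shows a higher number, and that gap lies beyond the scatter. Compound 1 contributes only a limit, (the limit of > 3 h in this assay, at which 1 of the 3 values shown sits), so it cannot be ranked against the others.

The next step replaces the cyanoguanidine-bearing ring of compound 2 with the triazole that compound 3 also carries, now through a methylene: a group of 6 heavy atoms (3 carbon, 3 nitrogen; one five-membered aromatic ring with 3 hetero atoms) in place of a group of 8 heavy atoms (4 carbon, 4 nitrogen; one five-membered non-aromatic ring with 2 hetero atoms), on a saturated chain carbon bound to an aromatic carbon and a saturated chain carbon. The product is compound 4 `CC(C)C(Cc1nnc[nH]1)c1ccc(-c2ccc3cccc(F)c3c2)[nH]c1=O`.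

Among the measured compounds shown here, with no step between measured compounds covering this change, the expectation in this assay rests on compound 3, which carries the same five-membered aromatic ring with 3 hetero atoms and gives 1.76 h. A step of a 1.9-fold higher number from compound 2 to compound 4 (0.28 log units; within the scatter) is expected, upward and moderately beyond the scatter. Compound 4 is estimated at 1.2 h, with a range of 0.5 h to 3 h.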

Compound 4, half-life: 0.307 h
The estimate for compound 4 lay 3.9-fold (0.59 log units) above the measured number; the measured number lies below the stated range.
By their numbers in this assay, from the lowest: compound 4; then compound 2; then compound 3. At a limit, above all of these: compound 1.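

In this assay, placing (4H-1,2,4-triazol-3-yl)methyl on this saturated chain carbon instead of the cyanoguanidine-bearing ring gives a 2.1-fold lower number from compound 2 to compound 4 (0.31 log units; beyond the scatter), so on this core the exchange moves the number down rather than up. Among the compounds shown here, the step is modest but beyond the scatter, and it is the first reading in which only one place differs. Nothing measured in the series accounts for this step.

On these data alone, whether the same exchange moves the number the same way on the cores of compound 1 and compound 3 remains open. Also open, as far as these compounds go, is how a carboxylic acid, a primary amine or a longer chain carrying the triazole would read at this position.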